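Methylating the hydroxy oxygen of compound 1

The compounds below may be only part of what the source reports. "The series", "measured", "known", "first", "only" and "open" are said of these compounds alone.

Measured so far:
compound 1 `COc1cc(/C=C\Cc2cc(O)c3ccccc3c2)cc(OC)c1OC` gives 670 nM
compound 2 `COc1cc(/C=C/Cc2cc(O)c3ccccc3c2)cc(OC)c1OC` gives 56400 nM

Both values come from a functional assay on BMEC cells (Bos taurus) for antiproliferative activity; a lower number here means a stronger inhibitor, a higher number a weaker inhibitor. Compound 1 holds the lower of the two numbers. Among the measured compounds shown here, the only measured step, an 84-fold higher number from compound 1 to compound 2 (1.93 log units; beyond the scatter), is large, and it goes with the fact that compounds 1 and 2 differ only in the configuration as drawn. It therefore concerns the double bond and leaves the hydroxy group untouched. Compound 3 `COc1cc(/C=C\Cc2cc(OC)c3ccccc3c2)cc(OC)c1OC` keeps the Z double bond of compound 1 and changes hydroxy to methoxy: methyl in place of hydrogen on an oxygen on an aromatic ring. For the measured compounds named here, no measured step covers this change, so the configuration step gives no direct measure of its size. Starting from the lower number in the series, a moderate rise is expected, smaller than the configuration step. The expected change is a 2.7-fold higher number from compound 1 to compound 3 (0.43 log units; beyond the scatter), with a wide margin. For compound 3 the estimated value is 1800 nM, within an expected range of 300 nM to 11000 nM.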

Compound 3, half-maximal inhibitory concentration: 10000 nM
Compound 3: middle estimate off by 5.6-fold (0.74 log units), on the low side; the range from low to high includes it.
By their numbers in this assay, from the lowest: compound 1; then compound 3; then compound 2.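

In this assay, methyl in place of hydrogen on the oxygen on the aromatic ring gives a 15-fold higher number from compound 1 to compound 3 (1.17 log units; beyond the scatter), so this position responds strongly to a change of a single heavy atom. The earlier step, an 84-fold higher number from compound 1 to compound 2 (1.93 log units; beyond the scatter), left the hydroxy group in place; now two separate single changes from compound 1 are known, and each gives a large rise in the number. Nothing at hand explains the rise from hydroxy to methoxy.

Open, on these data alone, is whether the step follows from losing the hydroxy hydrogen or from adding the methyl, a question that an amine or a longer ethoxy chain at this place could help to separate. Also open, as far as these compounds go, is whether hydroxy to methoxy gives a step of similar size on the E double bond of compound 2.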